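The source may hold more compounds than are shown below. What is called first, only, known or untested is meant among the compounds shown, and "the series" means these compounds.

Within the data shown here, compound 1 `CC(C)Cc1nc(N)c2nn(-c3ccccc3)cc2n1` stands highest of the two numbers measured so far. In an assay on CHO cells for displacement of a labelled ligand from adenosine receptor A1 (Homo sapiens), read by scintillation counting, tested at 1 uM (on this read-out lower numbers stand for less inhibition and higher numbers for more inhibition at the one concentration tested (going by the name of the read-out)), compound 1 gives 49%, while compound 2 `CC(C)c1nc(N)c2nn(-c3ccccc3)cc2n1` gives 2%. Among the measured compounds shown here, the one step between them, a number 47 percentage points lower from compound 1 to compound 2 (beyond the scatter), shows that trimming the side chain at this position cost almost all of the inhibition. Compound 3 `COc1ccc(Cc2nc(N)c3nn(-c4ccccc4)cc3n2)cc1` has not yet been measured. It differs from compound 1 in this way: 4-methoxyphenyl in place of isopropyl on a saturated chain carbon bound to an aromatic carbon. The measured step bears on the same place on the shared core but runs the other way, shrinking the group rather than enlarging it, so it only shows that this position is sensitive; a much larger group with a ring could move the number either way. The estimate for compound 3 is therefore near its parent, 50%, within 15% to 85%, meaning an expected step of a number 1 percentage points higher from compound 1 to compound 3 (within the scatter) in this assay.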

Compound 3, a percentage reported as inhibition, at one concentration (the size of the read-out at that concentration, not a potency): 48%
For compound 3 the middle estimate is 2 percentage points above the measured one, within the range that was stated.
By their numbers in this assay, from the lowest: compound 2; then compounds 3 and 1 (each within the scatter of the next).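

Replacing isopropyl with 4-methoxyphenyl on a saturated chain carbon bound to an aromatic carbon gives a number 1 percentage points lower from compound 1 to compound 3 (within the scatter) in this assay. This position therefore accepts a group of 8 heavy atoms with a six-membered aromatic ring in place of one of 3 heavy atoms with no ring, with no change beyond the scatter. Among these compounds, the earlier step, a number 47 percentage points lower from compound 1 to compound 2 (beyond the scatter), showed only that a change here can remove nearly all of the inhibition, whereas compound 3 shows that a much larger group need not do so. Nothing measured here explains why the number holds across this change.

The compounds shown leave open how a plain phenyl, a pyridine ring or a carboxylic acid would read at the same place. They also leave open whether the methoxy oxygen plays any part.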